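A few compounds are considered here, and "the series" means these few. Any claim that something is new, unique, unknown or untested is made for them only; others in the source may bear on it.

Working notes on the series. All three measured compounds share a core; in a functional assay on MKN-45 cells (Homo sapiens) for inhibition, read by MTT assay, with a stated time of 72 h (a lower number here means a stronger inhibitor, a higher number a weaker inhibitor), compound 1 `COc1cc2c(Oc3ccc(NC(=O)c4nn(-c5ccccc5OC(F)(F)F)c(=O)cc4C)cc3F)ccnc2cc1OCCCN1CCCC1` gives 60 nM. Compound 2 `COc1cc2c(Oc3ccc(NC(=O)c4nn(-c5ccccc5OC(F)(F)F)c(=O)cc4C)cc3F)ccnc2cc1OCCCN1CCCCC1` gives 40 nM in this assay. Compound 3 `COc1cc2c(Oc3ccc(NC(=O)c4nn(-c5ccc(Cl)cc5)c(=O)cc4C)cc3F)ccnc2cc1OCCCN1CCCC1` gives 150 nM in this assay, the highest of the three numbers.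

The cores of compound 1 and compound 3 differ by 4-chlorophenyl in place of 2-(trifluoromethoxy)phenyl on an aromatic nitrogen, and that change made a 2.5-fold higher number from compound 1 to compound 3 (0.40 log units; beyond the scatter).

The change from compound 1 to compound 2 is piperidin-1-yl in place of pyrrolidin-1-yl on a saturated chain carbon, three bonds along the chain from an oxygen on an aromatic ring, which made a 1.5-fold lower number from compound 1 to compound 2 (0.18 log units; within the scatter).

Compound 4 `COc1cc2c(Oc3ccc(NC(=O)c4nn(-c5ccc(Cl)cc5)c(=O)cc4C)cc3F)ccnc2cc1OCCCN1CCCCC1` is not yet measured in this assay. It differs from compound 3 by piperidin-1-yl in place of pyrrolidin-1-yl on a saturated chain carbon, three bonds along the chain from an oxygen on an aromatic ring, the same change as from compound 1 to compound 2, made at the same place and differing only in the core as set out above. For compound 4 the expected step is a 1.5-fold lower number from compound 3 to compound 4 (0.18 log units; within the scatter), resting on a 1.5-fold lower number from compound 1 to compound 2 (0.18 log units; within the scatter) carried over onto compound 3 with 150 nM. Compound 4 is therefore estimated at 100 nM in this assay, between 50 nM and 200 nM.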

Compound 4, half-maximal inhibitory concentration: 230 nM
The estimate for compound 4 lay 2.3-fold (0.36 log units) below the measured number; measured number above the stated range.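

On the core of compound 3, piperidin-1-yl in place of pyrrolidin-1-yl gives a 1.5-fold higher number from compound 3 to compound 4 (0.19 log units; within the scatter), and beside the earlier step on the core of compound 1 the two do not differ: the same change on two cores in this assay, a 1.5-fold lower number (0.18 log units; within the scatter) from compound 1 to compound 2 and a 1.5-fold higher number (0.19 log units; within the scatter) from compound 3 to compound 4, 2.3-fold (0.36 log units) apart, within the scatter of two such steps. With piperidin-1-yl in the chain, 4-chlorophenyl in place of 2-(trifluoromethoxy)phenyl gives a 5.8-fold higher number from compound 2 to compound 4 (0.76 log units; beyond the scatter), and this step likewise does not differ from the one seen with pyrrolidin-1-yl: the same change on two cores in this assay, a 2.5-fold higher number (0.40 log units; beyond the scatter) from compound 1 to compound 3 and a 5.8-fold higher number (0.76 log units; beyond the scatter) from compound 2 to compound 4, 2.3-fold (0.36 log units) apart, within the scatter of two such steps. These four compounds give no sign that either change depends on the core carrying it, but they do not establish that the changes carry over unaltered, and with one pair on each of two cores no rule for other cores follows.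

The compounds shown leave open how a morpholine or a piperazine in place of the ring amine, or a longer chain than 3-(piperidin-1-yl)propyl, would behave on these cores. They also leave open what an unsubstituted phenyl on the aromatic nitrogen would give.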